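Moving a trifluoromethyl group around a benzyl ring

The source may hold more compounds than are shown below. What is called first, only, known or untested is meant among the compounds shown, and "the series" means these compounds.

Of the compounds shown here, three sharing one core have been measured in an ADME assay on microsomes from liver (Homo sapiens) for metabolic stability, read by LC-MS, using NADPH, tested at 5 uM; on this read-out higher numbers stand for a longer-lived compound and lower numbers for a shorter-lived compound. Compound 1 `C/C(C#Cc1ccccc1)=N\N/C(N)=N/S(=O)(=O)c1cc(C)c(Cl)cc1SCc1ccccc1` carries a plain benzyl group on the sulfur and gives 0.466 h. Compound 2 `C/C(C#Cc1ccccc1)=N\N/C(N)=N/S(=O)(=O)c1cc(C)c(Cl)cc1SCc1ccc(C)cc1` gives 0.178 h, a change of a 2.6-fold lower number from compound 1 to compound 2 (0.42 log units; beyond the scatter). Compound 3 `C/C(C#Cc1ccccc1)=N\N/C(N)=N/S(=O)(=O)c1cc(C)c(Cl)cc1SCc1ccccc1C(F)(F)F` gives 0.107 h, a change of a 4.4-fold lower number from compound 1 to compound 3 (0.64 log units; beyond the scatter), while the direct comparison of compound 2 with compound 3 reads a 1.7-fold lower number from compound 2 to compound 3 (0.22 log units; within the scatter). On these numbers compound 3 stands lowest of the three, close to compound 2 and clearly separated from compound 1.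

Compound 4 `C/C(C#Cc1ccccc1)=N\N/C(N)=N/S(=O)(=O)c1cc(C)c(Cl)cc1SCc1cccc(C(F)(F)F)c1` keeps the same atoms and differs from compound 3 only in where the trifluoromethyl sits: 3-(trifluoromethyl)phenyl in place of 2-(trifluoromethyl)phenyl on a saturated chain carbon bound to a sulfur. For the measured compounds named here, none of the measured steps tests this kind of shift, since each of them either adds a group to the ring or exchanges one substituted ring for another. The two ring-substituted compounds, compound 2 and compound 3, fall within the scatter of each other, which suggests that details of the substituent matter little once one is present.

The expectation for compound 4 in this assay is therefore no step beyond the scatter, a 1.1-fold higher number from compound 3 to compound 4 (0.05 log units; within the scatter), with an estimated value of 0.12 h and a likely range from 0.05 h to 0.28 h.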

Compound 4, half-life: 0.13 h
Compound 4: middle estimate off by 1.1-fold (0.03 log units), on the low side, and the stated range covers the measured number.
By their numbers in this assay, from the lowest: compounds 3, 4 and 2 (each within the scatter of the next); then compound 1.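

In this assay, moving the trifluoromethyl group from the 2-(trifluoromethyl)phenyl to the 3-(trifluoromethyl)phenyl arrangement, on the saturated chain carbon bound to a sulfur, gives a result that cannot be told apart from no change (a 1.2-fold higher number from compound 3 to compound 4 (0.08 log units; within the scatter)), so these two placements on the ring cannot be separated in this read-out. Compound 4 also cannot be separated from the methyl-bearing ring of compound 2 (a 1.4-fold lower number from compound 2 to compound 4 (0.14 log units; within the scatter)), yet it stays clearly apart from the plain benzyl group (a 3.6-fold lower number from compound 1 to compound 4 (0.55 log units; beyond the scatter)), so among these four compounds, all three substituted rings sit apart from compound 1 and none goes against this pattern. The data shown offer no explanation for why the three substituted rings group together in this way.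

From the compounds shown here alone, it remains open whether a benzyl ring carrying an amine or a carboxylic acid instead of methyl or trifluoromethyl would stay with these three or come closer to compound 1 (0.466 h). How a longer chain between the sulfur and the ring would read is also left open.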